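Replacing a Hydroxyethyl Chain with Fluorophenyl on the Triazole

The compounds below may be only part of what the source reports. "The series", "measured", "known", "first", "only" and "open" are said of these compounds alone.

Measured compounds:
Compound 1 `COc1nc2ccc(Br)cc2cc1C(c1ccccc1)n1cc(CCCO)nn1`: 14.7%
Compound 2 `COc1nc2ccc(Br)cc2cc1C(c1ccccc1)n1cc(CCO)nn1`: 15.5%

In an ADME assay on PC-3 cells (Homo sapiens) for cytotoxicity, read by sulforhodamine B assay, with a stated time of 48 h, tested at 10 uM (a lower number here means less inhibition, a higher number more inhibition at the concentration tested (going by the name of the read-out)), compound 1 gives 14.7% and compound 2 gives 15.5%; the two numbers lie within the scatter of each other, so compound 2 cannot be told apart from compound 1. For the measured compounds named here, the only measured step, a number 0.8 percentage points higher from compound 1 to compound 2 (within the scatter), swapped hydroxy for hydroxymethyl and stayed within the scatter. Compound 3 `COc1nc2ccc(Br)cc2cc1C(c1ccccc1)n1cc(-c2ccc(F)cc2)nn1` carries 4-fluorophenyl in place of 2-hydroxyethyl on an aromatic carbon. Going by the values given here, that change has nothing in common with the single measured step, which therefore gives no guide to direction or size. The value of compound 3 in this assay is estimated at 18%, between 3% and 40%, meaning an expected step of a number 2.5 percentage points higher from compound 2 to compound 3 (within the scatter).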

Compound 3, a percentage reported as inhibition, at one concentration (the size of the read-out at that concentration, not a potency): 16.4%
For compound 3 the middle estimate is 1.6 percentage points above the measured one; measured number inside the range.
By their numbers in this assay, from the lowest: compounds 1, 2 and 3 (each within the scatter of the next).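

At this carbon of the five-membered aromatic ring with 3 nitrogen, a far larger swap than the earlier chain change still separates nothing in this assay: 4-fluorophenyl in place of 2-hydroxyethyl gives a number 0.9 percentage points higher from compound 2 to compound 3 (within the scatter) and 4-fluorophenyl in place of 3-hydroxypropyl gives a number 1.7 percentage points higher from compound 1 to compound 3 (within the scatter). Replacing a chain that has a hydrogen-bond donor with a ring that has none therefore leaves the compounds indistinguishable here. No supporting measurement offers an explanation. Going by these compounds, whether an amine, a carboxylic acid or a longer chain at this carbon would move the number beyond the scatter stays open, as does whether plain phenyl would match 4-fluorophenyl.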